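A Ring-Amine Swap Beyond the Assay Ceiling

The compounds below may be only part of what the source reports. "The series", "measured", "known", "first", "only" and "open" are said of these compounds alone.

Measured compounds:
Compound 1, `Clc1ccc(-c2nc(N3CCCCC3)c3nc[nH]c3n2)cc1`, in an assay on cells for displacement of a labelled ligand from adenosine receptor A3 (Homo sapiens), read by scintillation counting and radioligand binding, with a stated time of 180 min, tested at 10 uM (on this read-out lower numbers stand for less inhibition and higher numbers for more inhibition at the one concentration tested (going by the name of the read-out)), compound 1 gives > 80%, which is a limit of the assay rather than a number.
Compound 2, `Oc1cccc(-c2nc(N3CCCCC3)c3nc[nH]c3n2)c1`, in this assay compound 2 gives > 80%, again a limit and not a number.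

Both measured compounds therefore sit at the same ceiling, (the limit of > 80% in this assay, at which 2 of the 2 values shown sit), so the step that the two limits leave unreadable from compound 1 to compound 2 cannot be read in size or direction. Compound 1 stands at that limit, with nothing more precise known about how far beyond it the true inhibition lies.

The unmeasured compound 3, `CN1CCN(c2nc(-c3ccc(Cl)cc3)nc3[nH]cnc23)CC1`, keeps the 4-chlorophenyl group of compound 1 and alters only the saturated ring attached to the shared core: 4-methylpiperazin-1-yl in place of piperidin-1-yl on an aromatic carbon. Among the measured compounds shown here, no measured step touches this position, so the two values at the limit give no guide to the size of the change, only that compound 1 starts high.

With that in mind, the expected step of a number at least 10 percentage points lower from compound 1 to compound 3 (that floor lies within the scatter) is modest and downward but uncertain, and compound 3 is estimated to give 70%, within a range from 35% to 95% in this assay.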

Compound 3, a percentage reported as inhibition, at one concentration (the size of the read-out at that concentration, not a potency): > 80%
Compound 3 was reported as a limit; the forecaster's own chance of this, stated with the estimate: 0.45%; at least 10 percentage points between middle value and limit.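

In this assay compound 3 gives > 80%, a limit of the assay and not a number. No step from compound 1 to compound 3 can be read, because both stand at the same ceiling: the limit of > 80% in this assay, at which 3 of the 3 values shown sit.

From the compounds shown here alone, how far each compound lies beyond that limit, and whether swapping piperidin-1-yl for 4-methylpiperazin-1-yl changes inhibition at all, remains open.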